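The source may hold more compounds than are shown below. What is called first, only, known or untested is meant among the compounds shown, and "the series" means these compounds.

For the measured compounds named here, compound 1 `COc1ccc(-c2cn3cc(-c4ccccc4)nc(NC(=O)c4ccccc4)c3n2)cc1` is the one of the two measured members with the lower number: in an assay on cells for displacement of a labelled ligand from adenosine receptor A1 (Homo sapiens), read by scintillation counting, with a stated time of 120 min, tested at 1 uM (a lower number here means less inhibition, a higher number more inhibition at the concentration tested (going by the name of the read-out)), compound 1 gives 3%. Going by the values given here, compound 2 `COc1cccc(-c2cn3cc(-c4ccccc4)nc3c(N)n2)c1` carries a free amino group on the shared core and a 3-methoxyphenyl on the aromatic carbon described below; in this assay compound 2 gives 37%, the highest of the two numbers so far, and the nearest number, that of compound 1, lies lower by a margin beyond the scatter. Among the compounds with values here, no pair of measured compounds differs in one place only, so no single-point step has been recorded.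

Compound 3 `Nc1nc(-c2ccc(Cl)cc2)cn2cc(-c3ccccc3)nc12` is the next compound for this assay. Compared with compound 2 it changes at one place: 4-chlorophenyl in place of 3-methoxyphenyl on an aromatic carbon

Within the data shown here, with no recorded step to lean on, the expectation for the step from compound 2 to compound 3 rests on the value of compound 2 in this assay alone, and the step is expected to be small, a number 7 percentage points lower from compound 2 to compound 3 (within the scatter), most likely not beyond the scatter in either direction. Compound 3 is therefore estimated at 30% in this assay, in a range from 8% to 55%.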

Compound 3, a percentage reported as inhibition, at one concentration (the size of the read-out at that concentration, not a potency): 3%
Compound 3: middle estimate off by 27 percentage points, on the high side, outside the stated range (below it).
By their numbers in this assay, from the lowest: compounds 1 and 3 (each within the scatter of the next); then compound 2.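

In this assay, for the compounds shown here, the exchange of 3-methoxyphenyl for 4-chlorophenyl on the aromatic carbon next to the ring nitrogen provides the first single-place step, and it is large: a number 34 percentage points lower from compound 2 to compound 3 (beyond the scatter). This position is therefore not indifferent to the choice of substituted phenyl when the free amino group and the rest of the shared core stay unchanged, which the earlier pair, differing in more than one place, could not show. No measurement at hand bears on the reason for this step.

The change alters both the substituent, methoxy to chlorine, and its place on the phenyl ring, so the compounds shown do not separate the effect of the substituent from that of its ring position, and a 3-chlorophenyl on the same carbon would be the direct link between compound 2 and compound 3. Also open, on these data alone, is whether the 3-methoxy group itself matters at this carbon, a question that 3-hydroxyphenyl or 3-ethoxyphenyl would address on the same amino-bearing core.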